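Methoxyphenyl to Nitrophenyl on a Thiosemicarbazone Tail

The source may hold more compounds than are shown below. What is called first, only, known or untested is meant among the compounds shown, and "the series" means these compounds.

Of the compounds shown here, three on a shared core have been measured. Compound 1 `CC1=CC[C@@H]([C@@](C)(O)CCCC(C)(C)NC=S)CC1` carries the simplest thiocarbonyl group. In a functional assay on MCF7 cells (Homo sapiens) for cytotoxicity, read by sulforhodamine B assay (a lower number here means that less compound is tolerated, a higher number that more compound is tolerated), compound 1 gives > 100000 nM, which is a limit of the assay and not a number. Compound 2 `CC1=CC[C@@H]([C@@](C)(O)CCCC(C)(C)NC(=S)NN)CC1` places aminoamino in place of hydrogen on the thiocarbonyl carbon. In this assay compound 2 gives > 100000 nM, again a limit. Compound 3 `COc1ccc(/C=N\NC(=S)NC(C)(C)CCC[C@](C)(O)[C@@H]2CC=C(C)CC2)cc1` carries the 4-methoxyphenyl hydrazone. In this assay compound 3 gives > 100000 nM, likewise a limit. Compound 3 thus stands at the limit, and so do the two other values shown (the limit of > 100000 nM in this assay, at which 3 of the 3 values shown sit). The steps a step that the two limits leave unreadable from compound 1 to compound 2 and a step that the two limits leave unreadable from compound 2 to compound 3 cannot be sized, because both ends are limits (the limit of > 100000 nM in this assay, at which 3 of the 3 values shown sit).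

Compound 4 `CC1=CC[C@@H]([C@@](C)(O)CCCC(C)(C)NC(=S)N/N=C\c2ccccc2[N+](=O)[O-])CC1` differs from compound 3 by 2-nitrophenyl in place of 4-methoxyphenyl on a carbon with a double bond to nitrogen. Within the data shown here, no measured step covers such an exchange on the hydrazone carbon, and the measured steps give neither size nor direction. The expectation is therefore that nothing beyond the scatter appears and that the assay again reports a limit; the expected step is a step that the limit leaves unreadable from compound 3 to compound 4. Compound 4 is estimated at 150000 nM, between 40000 nM and 600000 nM.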

Compound 4, concentration lethal to 50% of the cells: > 100000 nM
Compound 4: no number, only a limit (the forecaster's own chance of this, stated with the estimate: 80%); the middle value lies beyond the limit too.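

Compound 4, like compound 3, stands at a limit in this assay, so the exchange of 4-methoxyphenyl for 2-nitrophenyl cannot be read as a step: the limit of > 100000 nM in this assay, at which 4 of the 4 values shown sit. The compounds shown leave open whether any group on the shared core would bring a readable number in this assay.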